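A few compounds are considered here, and "the series" means these few. Any claim that something is new, unique, unknown or untested is made for them only; others in the source may bear on it.

Compound 1 `CCc1cccc(CNC(=O)c2nc3cccc(COCc4ccc(C(=O)O)cc4)c3c(=O)[nH]2)c1`: > 40000 nM
Compound 2 `CCc1cccc(CNC(=O)c2nc3ccc(OC)c(COCc4ccc(C(=O)O)cc4)c3c(=O)[nH]2)c1`: > 20000 nM
Compound 3 `CCc1cccc(CNC(=O)c2nc3cccc(CSCc4ccc(C(=O)O)cc4)c3c(=O)[nH]2)c1`: > 20000 nM

Among the compounds with values here, in an ADME assay on HEK293 cells (Homo sapiens) for cytotoxicity, read by resazurin assay, with a stated time of 72 h (a higher number here means that more compound is tolerated, a lower number that less compound is tolerated), no compound so far has given a true number. Compound 1 gives > 40000 nM, which is a limit of the assay and not a number. Compound 2 gives > 20000 nM, also a limit. Compound 3 gives > 20000 nM, again a limit.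

The next compound, compound 4 `O=C(O)c1ccc(COCc2cccc3nc(C(=O)NCc4cccc(C(F)(F)F)c4)[nH]c(=O)c23)cc1`, carries trifluoromethyl in place of ethyl on an aromatic carbon, meta to a large group: trifluoromethyl in place of ethyl on an aromatic carbon.

Neither measured change touches the ethyl group, so both bear on this one only loosely. Methoxy in place of hydrogen on an aromatic carbon gave a step that the two limits leave unreadable from compound 1 to compound 2. Swapping (4-carboxybenzyl)oxy for (4-carboxybenzyl)sulfanyl gave a step that the two limits leave unreadable from compound 1 to compound 3. Neither size can be read, and they suggest no direction, so no change beyond the usual scatter is expected in this assay. The expected result is a number no higher from compound 1 to compound 4 (the limit leaves the size open). Another limit rather than a number would be the likeliest reading. For compound 4 the estimate is 40000 nM, with an expected range from 20000 nM to 80000 nM.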

Compound 4, half-maximal cytotoxic concentration: > 20000 nM
Compound 4 was reported as a limit (the forecaster's own chance of this, stated with the estimate: 85%); the middle value does not contradict the limit.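

In this assay compound 4 gives > 20000 nM, a limit of the assay and not a number. Compound 1 also stands at a limit, so the step between compound 1 and compound 4 cannot be read. What the compounds shown leave open is the concentration at which any of them becomes toxic to these cells.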